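Benzyl for isopropyl on the ring nitrogen of compound 2

A few compounds are considered here, and "the series" means these few. Any claim that something is new, unique, unknown or untested is made for them only; others in the source may bear on it.

Three compounds share a core, and two of them carry a number in a functional assay on CEM/s cells (Homo sapiens) for cytotoxicity; on this read-out higher numbers stand for weaker inhibition and lower numbers for stronger inhibition. Compound 1 `Cn1c[n+](Cc2ccccc2)c2/c(=N/OC(C)(C)C)[nH]cnc21` gives "not determined" (no result reported) in this assay, so no number is known for it. Compound 2 `CO/N=c1\[nH]cnc2c1[n+](C/C=C(\C)CC/C=C(\C)CC/C=C(\C)CCC=C(C)C)cn2C(C)C` gives 2050 nM in this assay, the lowest of the two numbers. Going by the values given here, compound 3 `CC(C)=CCC/C(C)=C/CC/C(C)=C/CC/C(C)=C/C[n+]1cn(CCC#N)c2nc[nH]/c(=N\OCc3ccccc3)c21` gives 19100 nM in this assay, a gap to compound 2 that lies beyond the usual scatter; as the two differ in several places at once, no single step is set out between them.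

Compound 4 `CO/N=c1\[nH]cnc2c1[n+](C/C=C(\C)CC/C=C(\C)CC/C=C(\C)CCC=C(C)C)cn2Cc1ccccc1` has not yet been measured. It departs from compound 2 by benzyl in place of isopropyl on an aromatic nitrogen. Among the compounds with values here, no measured pair shows what such an exchange does on this core, so the expectation rests on compound 2 alone. The step of a 1.3-fold lower number from compound 2 to compound 4 (0.11 log units; within the scatter) is expected to stay within the usual scatter, with no clear direction. Compound 4 is therefore expected to give about 1600 nM in this assay, with a range from 500 nM to 5000 nM.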

Compound 4, half-maximal inhibitory concentration: 2240 nM
The estimate for compound 4 lay 1.4-fold (0.15 log units) below the measured number; the range from low to high includes it.
By their numbers in this assay, from the lowest: compounds 2 and 4 (each within the scatter of the next); then compound 3.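

In this assay, benzyl in place of isopropyl on the aromatic nitrogen of the five-membered ring gives a 1.1-fold higher number from compound 2 to compound 4 (0.04 log units; within the scatter) and is the only single-place change among these compounds. The result shows that, with the rest of compound 2 held fixed, a group of 7 heavy atoms carrying a six-membered aromatic ring can stand at this position in place of one of 3 heavy atoms without the read-out moving beyond the scatter. No measured evidence here bears on why the number holds.

The compounds shown leave open whether an amine, a carboxylic acid or a longer alkyl chain at this ring nitrogen would change the number beyond the scatter. From the compounds shown here alone, it also remains open whether the exchange of isopropyl for benzyl would give the same result with a different group on the other side of the shared core.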